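Methyl in Place of Hydrogen on the Benzamide Ring

A few compounds are considered here, and "the series" means these few. Any claim that something is new, unique, unknown or untested is made for them only; others in the source may bear on it.

Compound 1 `Cc1cc(=O)[nH]c2cc(NC(=O)c3ccccc3)ccc12`: 1.66
Compound 2 `Cc1cc(=O)[nH]c2cc(NC(=O)c3ccc(Cl)cc3Cl)ccc12`: 1.83

Of the compounds shown here, two have so far been measured in a physicochemical assay for lipophilicity; on this read-out lower numbers stand for lower lipophilicity and higher numbers for higher lipophilicity. Compound 1 gives 1.66, and compound 2 gives 1.83. Compound 1 stands at one end of these two numbers, but its nearest neighbour, compound 2, lies within the usual scatter of it, so the two cannot be told apart on this assay.

Compound 3 `Cc1ccc(C(=O)Nc2ccc3c(C)cc(=O)[nH]c3c2)cc1` has not yet been measured. It differs from compound 1 by methyl in place of hydrogen on an aromatic carbon, a methyl in place of hydrogen on an aromatic carbon. Going by the values given here, no pair of measured compounds shows this single change, so the expectation rests on the change alone. A modest rise in this assay is expected, a step of a number 0.34 log units higher from compound 1 to compound 3 (beyond the scatter) from compound 1 to compound 3. Compound 3 is therefore estimated to give about 2, with a range from 1.7 to 2.35.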

Compound 3, partition coefficient: 1.67
Compound 3: middle estimate off by 0.33 log units, on the high side; the measured number lies below the stated range.
By their numbers in this assay, from the lowest: compounds 1, 3 and 2 (each within the scatter of the next).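

Going by these compounds alone, at this place, para to a large group on a six-membered aromatic ring of carbon only, the first step to be read is phenyl to 4-methylphenyl, and in this assay it comes out as a number 0.01 log units higher from compound 1 to compound 3 (within the scatter), so compound 1 and compound 3 cannot be told apart on this read-out. Methyl in place of hydrogen on this aromatic carbon therefore leaves the number within the scatter in this one pair, which the two earlier compounds, differing in more than one place, could not show. Nothing measured here offers an explanation for this result.

On these data alone, whether a different group at this same place, such as an amine, a carboxylic acid or a longer chain, would give a step beyond the scatter remains open. So does whether methyl on another carbon of this ring would read the same way.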